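From 5-methylpyrazin-2-yl to pyrazin-2-yl in compound 1

The compounds below may be only part of what the source reports. "The series", "measured", "known", "first", "only" and "open" are said of these compounds alone.

Compounds measured in a functional assay on BXPC-3 cells (Homo sapiens) for inhibition, read by MTT assay, with a stated time of 72 h; on this read-out lower numbers stand for stronger inhibition and higher numbers for weaker inhibition

- Compound 1 `Cc1cnc(C(=O)Nc2cc(Cl)cc3cccnc23)cn1` gives 5200 nM
- Compound 2 `COc1cc(NC(=O)c2cnc(C)cn2)c2ncccc2c1` gives 6700 nM

Within the data shown here, compound 1 and compound 2 are the only measured compounds, and their values lie within the scatter of each other. Compound 3 `O=C(Nc1cc(Cl)cc2cccnc12)c1cnccn1` awaits measurement and differs from compound 1 by hydrogen in place of methyl on an aromatic carbon. Among the measured compounds shown here, the one measured step, a 1.3-fold higher number from compound 1 to compound 2 (0.11 log units; within the scatter), concerns methoxy in place of chloro, so it offers only indirect guidance on hydrogen in place of methyl. No shift beyond the scatter is therefore expected in this assay, and no direction is favoured. The expected change is a 1.2-fold higher number from compound 1 to compound 3 (0.06 log units; within the scatter). Compound 3 is estimated at 6000 nM, within an expected range of 2500 nM to 15000 nM.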

Compound 3, half-maximal inhibitory concentration: > 10000 nM
Compound 3: no number, only a limit; the forecaster's own chance of this, stated with the estimate: 10%; at least 1.6-fold (0.22 log units) between middle value and limit.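

Compound 1 and compound 2 both carry the methyl, so neither showed what happens when it leaves this position, on an aromatic carbon para to a large group. In this assay compound 3 gives > 10000 nM, which is a limit and not a number: the limit of > 10000 nM in this assay, at which 1 of the 3 values shown sits.

Hydrogen in place of methyl therefore reads only as an at least 1.9-fold higher number from compound 1 to compound 3 (0.28 log units; that floor lies within the scatter), so the change has a floor but no measured size. The compounds shown leave open how far compound 3 lies past that limit, and how an ethyl or an amine at this position would read.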